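The source may report more compounds than this note shows. Statements on the series, on what has been measured and on what is new or still open speak of the compounds shown alone.

In a functional assay on A549 cells (Homo sapiens) for inhibition, read by sulforhodamine B assay (on this read-out lower numbers stand for stronger inhibition of growth and higher numbers for weaker inhibition of growth), compound 3 `Oc1cccc2[nH]c(-c3ccc(-c4ccc(-c5cccc(Cl)c5)cc4)cc3)nc12` has the highest number of the three measured, at 2400 nM, against compound 1 `Oc1cccc2[nH]c(-c3ccc(-c4ccc(-c5ccc(F)cc5)cc4)cc3)nc12` at 170 nM and compound 2 `Oc1ccc(-c2ccc(-c3ccc(-c4nc5c(O)cccc5[nH]4)cc3)cc2)cc1` at 170 nM. Compound 4 `COc1ccc(-c2ccc(-c3ccc(-c4nc5c(O)cccc5[nH]4)cc3)cc2)cc1OC` carries 3,4-dimethoxyphenyl in place of 3-chlorophenyl on an aromatic carbon. Two large measured steps bear on this, a 14-fold higher number from compound 1 to compound 3 (1.15 log units; beyond the scatter) and a 14-fold higher number from compound 2 to compound 3 (1.15 log units; beyond the scatter), while no change at the digits printed from compound 1 to compound 2 (within the scatter) stays within the scatter. The entering group matches neither 4-fluorophenyl nor 4-hydroxyphenyl, so only part of that gap is expected to be recovered, in the direction of a lower number in this assay. The expected change is a 4.0-fold lower number from compound 3 to compound 4 (0.60 log units; beyond the scatter). For compound 4 the estimated value is 600 nM, with an expected range of 150 nM to 2500 nM.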

Compound 4, concentration for 50% growth inhibition: 1310 nM
The estimate for compound 4 lay 2.2-fold (0.34 log units) below the measured number; measured number inside the range.
By their numbers in this assay, from the lowest: compounds 1 and 2 (each within the scatter of the next); then compounds 4 and 3 (each within the scatter of the next).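

In this assay, 3,4-dimethoxyphenyl does not separate from 3-chlorophenyl on this aromatic carbon: a 1.8-fold lower number from compound 3 to compound 4 (0.26 log units; within the scatter) stays within the scatter. The other two steps, a 7.7-fold higher number from compound 2 to compound 4 (0.89 log units; beyond the scatter) and a 7.7-fold higher number from compound 1 to compound 4 (0.89 log units; beyond the scatter), lie beyond it, so among these four compounds 3,4-dimethoxyphenyl groups with 3-chlorophenyl, not with 4-fluorophenyl or 4-hydroxyphenyl.

As far as these compounds go, whether 4-methoxyphenyl, 3-hydroxyphenyl or 4-aminophenyl falls with the lower or the higher numbers remains open. No available evidence accounts for the gap between the two pairs.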